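The source may hold more compounds than are shown below. What is called first, only, known or untested is meant among the compounds shown, and "the series" means these compounds.

The measured compounds:

- compound 1, `CC1CC/C(=N\Nc2cccc(Br)c2)c2ncc(C(=O)O)c(=O)n21`: in a functional assay on the whole organism for inhibition, with Rattus norvegicus as the target (on this read-out higher numbers stand for an effect only at larger amounts of compound and lower numbers for an effect already at smaller amounts), compound 1 gives > 320 umol/kg, which is a limit of the assay and not a number.
- compound 2, `CC1CC/C(=N\Nc2cccc(C(=O)O)c2)c2ncc(C(=O)O)c(=O)n21`: in this assay compound 2 gives > 100 umol/kg, likewise a limit of the assay rather than a number.

Compound 2 thus stands at a limit only, with no measured number of its own; of the two values shown, both are limits. Within the data shown here, the one measured step, from compound 1 to compound 2, is a step that the two limits leave unreadable from compound 1 to compound 2, carboxy in place of bromo on an aromatic carbon, and its size cannot be read because the limit of > 320 umol/kg in this assay, at which 1 of the 2 values shown sits, and the limit of > 100 umol/kg in this assay, at which 1 of the 2 values shown sits, are both limits.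

Compound 3, `CCOC(=O)c1cccc(N/N=C2\CCC(C)n3c2ncc(C(=O)O)c3=O)c1`, differs from compound 2 by ethyl in place of hydrogen on an oxygen next to a carbonyl group. Among the measured compounds shown here, no measured step bears on this change, so nothing in the data points to a shift in either direction in this assay beyond the usual scatter. On this basis compound 3 is estimated in this assay at 200 umol/kg, with a range from 60 umol/kg to 1000 umol/kg. The expected step is a step that the limit leaves unreadable from compound 2 to compound 3, which amounts to no change beyond the scatter, and another limit rather than a number is thought likely.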

Compound 3, dose for 50% inhibition: > 100 umol/kg
Compound 3 gave a limit, no number; the forecaster's own chance of this, stated with the estimate: 70%; the middle value does not contradict the limit.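

Compound 3 adds no readable step in this assay: its result, like those of compound 1 and compound 2, is a limit of the assay and not a number. The compounds shown leave open what dose of any of the three gives the inhibition, and whether ethyl in place of hydrogen on an oxygen next to a carbonyl group changes it.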